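From 2-nitrophenyl to 4-chlorophenyl on a shared core

A few compounds are considered here, and "the series" means these few. Any claim that something is new, unique, unknown or untested is made for them only; others in the source may bear on it.

Compound 1 `CC1=CC[C@@H]([C@@](C)(O)CCCC(C)(C)NC(=S)N/N=C\c2ccc(N(C)C)cc2)CC1`: > 100000 nM
Compound 2 `CC1=CC[C@@H]([C@@](C)(O)CCCC(C)(C)NC(=S)N/N=C\c2ccccc2[N+](=O)[O-])CC1`: > 100000 nM

Both entries come from a functional assay on NCI-H460 cells (Homo sapiens) for cytotoxicity, read by sulforhodamine B assay (a lower number here means a stronger inhibitor of growth, a higher number a weaker inhibitor of growth), and neither is a number. In this assay compound 2 stands at > 100000 nM, which is a limit of the assay. Compound 1 gives > 100000 nM, which is also a limit. The whole measured picture so far is the limit of > 100000 nM in this assay, at which 2 of the 2 values shown sit.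

Compound 3 `CC1=CC[C@@H]([C@@](C)(O)CCCC(C)(C)NC(=S)N/N=C\c2ccc(Cl)cc2)CC1` is the next to be measured. Its change from compound 2 is 4-chlorophenyl in place of 2-nitrophenyl on a carbon with a double bond to nitrogen. The 4-chlorophenyl takes the place of the 2-nitrophenyl on a carbon with a double bond to nitrogen, and the rest of the shared core stays the same.

Going by the values given here, only one measured step bears on this aryl exchange, and it is a step that the two limits leave unreadable from compound 1 to compound 2. No size can be carried over from a step that the two limits leave unreadable from compound 1 to compound 2, so no clear step in this assay is expected in either direction, and another limit would be no surprise. The step expected is a number no higher from compound 2 to compound 3 (the limit leaves the size open). For compound 3 the estimated value is 100000 nM, with an expected range from 30000 nM to 300000 nM.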

Compound 3, concentration for total growth inhibition: > 100000 nM
Compound 3: a limit, no number; the forecaster's own chance of this, stated with the estimate: 70%; the middle value sits exactly at the limit.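

In this assay compound 3 gives > 100000 nM, which is a limit and not a number. Going by these compounds alone, no step can therefore be read among compound 1, compound 2 and compound 3: the limit of > 100000 nM in this assay, at which 3 of the 3 values shown sit. The compounds shown leave open whether the 4-(dimethylamino)phenyl, 2-nitrophenyl and 4-chlorophenyl groups on the shared core differ at all in growth inhibition.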